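Swapping the benzylamine for a methoxypiperidine on the pyridine

The compounds below may be only part of what the source reports. "The series", "measured", "known", "first", "only" and "open" are said of these compounds alone.

Measured compounds:
compound 1 `CC(C(=O)NCc1ccc(C(F)(F)F)nc1Nc1ccccc1)c1ccc(NS(C)(=O)=O)c(F)c1` gives 1400 nM
compound 2 `CC(C(=O)NCc1ccc(C(F)(F)F)nc1NCc1ccc(Cl)cc1)c1ccc(NS(C)(=O)=O)c(F)c1` gives 414 nM
compound 3 `C[C@H](C(=O)NCc1ccc(C(F)(F)F)nc1N1CC[C@@H](OCc2ccccc2)C1)c1ccc(NS(C)(=O)=O)c(F)c1` gives 50 nM

All three were tested in a functional assay on CHO-K1 cells for antagonist activity at transient receptor potential cation channel subfamily V member 1 (Homo sapiens), read by FLIPR; a higher number here means a weaker inhibitor, a lower number a stronger inhibitor. Compound 2 stands second highest of the three numbers; compound 1 sits a step above it, and compound 3 lies well below both, giving the lowest number of the set.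

Compound 4 `COC1CCN(c2nc(C(F)(F)F)ccc2CNC(=O)C(C)c2ccc(NS(C)(=O)=O)c(F)c2)CC1` differs from compound 2 in one place: 4-methoxypiperidin-1-yl in place of (4-chlorobenzyl)amino on an aromatic carbon.

For the measured compounds named here, the only single step known here is a 3.4-fold lower number from compound 1 to compound 2 (0.53 log units; beyond the scatter), a change at the same position, which shows that this nitrogen tolerates quite different groups. Going by the values given here, compound 3 carries yet another group at that position and gives a far lower number than compound 2, though no single step links those two. On that basis compound 4 is expected to land below compound 2, estimated as a 2.1-fold lower number from compound 2 to compound 4 (0.32 log units; beyond the scatter), with a wide range. The estimate for compound 4 is therefore 200 nM, between 60 nM and 700 nM.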

Compound 4, half-maximal inhibitory concentration: 280 nM
Beside the measured number, compound 4's estimate is 1.4-fold (0.15 log units) below it, within the range that was stated.
By their numbers in this assay, from the lowest: compound 3; then compounds 4 and 2 (each within the scatter of the next); then compound 1.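

In this assay, the step of a 1.5-fold lower number from compound 2 to compound 4 (0.17 log units; within the scatter) shows that 4-methoxypiperidin-1-yl and (4-chlorobenzyl)amino cannot be told apart on this aromatic carbon. So this level of inhibition survives losing both the hydrogen-bond donor on the attached nitrogen and the six-membered aromatic ring of the leaving group, while the step of a 5.0-fold lower number from compound 1 to compound 4 (0.70 log units; beyond the scatter) stays beyond the scatter when anilino is the group replaced. Nothing measured here explains why these groups compare as they do.

As far as these compounds go, what remains open is whether the methoxy group itself contributes, which a plain piperidin-1-yl or a 4-hydroxypiperidin-1-yl on the same carbon would test. A morpholin-4-yl group, with the oxygen held inside the ring, would ask a related question about where that oxygen can sit.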